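The source may hold more compounds than are shown below. What is called first, only, known or untested is meant among the compounds shown, and "the series" means these compounds.

In a functional assay on DU-145 cells (Homo sapiens) for cytotoxicity, read by MTT assay, with a stated time of 68 h (on this read-out higher numbers stand for weaker inhibition and lower numbers for stronger inhibition), compound 1 (`O=C(/C=C/c1cccc(OCc2ccccc2)c1)c1ccc([N+](=O)[O-])cc1`) gives 52500 nM, compound 2 (`O=C(/C=C/c1cccc(OCc2ccccc2)c1)c1ccc(Cl)cc1Cl`) gives 27300 nM, and compound 3 (`O=C(/C=C/c1cccc(OCc2ccccc2)c1)c1ccc(Br)cc1`) gives 5700 nM, the lowest of the three numbers. Compound 4 (`Cc1ccc(C(=O)/C=C/c2cccc(OCc3ccccc3)c2)cc1`) has methyl in place of bromo on an aromatic carbon. Within the data shown here, two measured steps bear on this change, as both end at the bromo compound: a 9.2-fold lower number from compound 1 to compound 3 (0.96 log units; beyond the scatter) and a 4.8-fold lower number from compound 2 to compound 3 (0.68 log units; beyond the scatter). Both are modest, so swapping groups here can move the number, but neither involves methyl, and the data give no firm direction. A small shift toward a higher number is therefore expected, with the estimated step being a 1.8-fold higher number from compound 3 to compound 4 (0.24 log units; within the scatter). For compound 4 the estimate is 10000 nM, with an expected range from 3500 nM to 30000 nM.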

Compound 4, half-maximal inhibitory concentration: 25600 nM
For compound 4 the middle estimate is 2.6-fold (0.41 log units) below the measured one; the measured number falls inside the stated range.
By their numbers in this assay, from the lowest: compound 3; then compounds 4, 2 and 1 (each within the scatter of the next, the first and the last beyond it).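

With a 4.5-fold higher number from compound 3 to compound 4 (0.65 log units; beyond the scatter) on going from bromo to methyl, this position tells apart two groups of the same heavy-atom count. With a 1.1-fold lower number from compound 2 to compound 4 (0.03 log units; within the scatter) the 4-methylphenyl compound stays level with the 2,4-dichlorophenyl one, and with a 2.1-fold lower number from compound 1 to compound 4 (0.31 log units; beyond the scatter) it stands only narrowly clear of the scatter against the nitro compound. As far as these compounds go, whether an amine or a longer chain such as ethyl at this place would come closer to bromo or to methyl stays open. Nothing available here says why bromo and methyl differ.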